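Nitro for methoxy, repeated on a second core

The compounds below may be only part of what the source reports. "The series", "measured", "known", "first", "only" and "open" are said of these compounds alone.

Compound 1, `COc1ccc(S(=O)(=O)Oc2ccccc2/C=C(\C#N)C(=O)Nc2nnc(-c3cccs3)s2)cc1`, gives 76% in a functional assay on RS4-11 cells (Homo sapiens) for inhibition, read by CCK-8 assay, with a stated time of 48 h, tested at 20 uM; on this read-out higher numbers stand for more inhibition of growth at the one concentration tested and lower numbers for less inhibition of growth.
Compound 2, `N#C/C(=C\c1ccccc1OS(=O)(=O)c1ccc([N+](=O)[O-])cc1)C(=O)Nc1nnc(-c2cccs2)s1`, gives 40% in this assay.
Compound 3, `COc1ccc(S(=O)(=O)Oc2ccccc2/C=C(\C#N)C(=O)Nc2nnc(Cc3cccc4ccccc34)s2)cc1`, gives 78% in this assay.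

Compound 1 and compound 3 lie within the scatter of each other. The change nitro in place of methoxy on an aromatic carbon produced a number 36 percentage points lower from compound 1 to compound 2 (beyond the scatter). The two cores differ by (naphthalen-1-yl)methyl in place of thiophen-2-yl on an aromatic carbon, which produced a number 2 percentage points higher from compound 1 to compound 3 (within the scatter).

Compound 4, `N#C/C(=C\c1ccccc1OS(=O)(=O)c1ccc([N+](=O)[O-])cc1)C(=O)Nc1nnc(Cc2cccc3ccccc23)s1`, is unmeasured. It differs from compound 3 by nitro in place of methoxy on an aromatic carbon, the same change at the same place as from compound 1 to compound 2. Because a number 36 percentage points lower from compound 1 to compound 2 (beyond the scatter) was seen for this change, the step to compound 4 is expected to be a number 36 percentage points lower from compound 3 to compound 4 (beyond the scatter). That rests on one prior pair only. Compound 4 is therefore estimated at 42%, likely between 25% and 60%.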

Compound 4, percent growth inhibition at one concentration: 58%
Compound 4: the middle estimate sits 16 percentage points below what was measured, within the range that was stated.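

In this assay, nitro in place of methoxy again gives a lower number on the second core, a number 20 percentage points lower from compound 3 to compound 4 (beyond the scatter), so the direction carries over but the size does not: the same change on two cores in this assay, a number 36 percentage points lower (beyond the scatter) from compound 1 to compound 2 and a number 20 percentage points lower (beyond the scatter) from compound 3 to compound 4, 16 percentage points apart, beyond the scatter of two such steps. Seen from the other side, (naphthalen-1-yl)methyl in place of thiophen-2-yl gives a number 18 percentage points higher from compound 2 to compound 4 (beyond the scatter), so across these four compounds the two changes do not simply add: the same change on two cores in this assay, a number 2 percentage points higher (within the scatter) from compound 1 to compound 3 and a number 18 percentage points higher (beyond the scatter) from compound 2 to compound 4, 16 percentage points apart, beyond the scatter of two such steps. Two cores show a shared direction only; they do not explain the difference in size or give a size to carry to a further core.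

Open, on these data alone, is how an amine or a chlorine in place of the methoxy would read on either core. Also open, as far as these compounds go, is whether a longer chain on the other side would follow either core.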